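This account rests on a few compounds, and the source may have more. Where it says the series, first, only, none or still open, it means among the compounds named here.

Compound 1 `Nc1sc(-c2ccc(Cl)cc2)c(-c2ccc(Cl)cc2)c1C(=O)N1CCCC1` gives 6220 nM in a functional assay on PC-3 cells (Homo sapiens) for inhibition, read by sulforhodamine B assay, with a stated time of 72 h; on this read-out higher numbers stand for weaker inhibition and lower numbers for stronger inhibition. Compound 2 `COc1ccc(CNC(=O)c2c(N)sc(-c3ccc(Cl)cc3)c2-c2ccc(Cl)cc2)cc1` gives 29500 nM. Compound 3 `CCCCNC(=O)c1c(N)sc(-c2ccc(Cl)cc2)c1-c1ccc(Cl)cc1` gives 17800 nM.

Compound 3 holds the second highest number of the three: it lies within the scatter of compound 2, while compound 1 sits clearly lower, the gap being a 2.9-fold higher number from compound 1 to compound 3 (0.46 log units; beyond the scatter). Compound 4 `Nc1sc(-c2ccc(Cl)cc2)c(-c2ccc(Cl)cc2)c1C(=O)N1CCOCC1` differs from compound 3 in one place: morpholin-4-yl in place of butylamino on a carbonyl carbon. The step that bears on this is a 2.9-fold higher number from compound 1 to compound 3 (0.46 log units; beyond the scatter), where a ring-closed amine gave way to an open butylamino and the number rose. Compound 4 returns to a ring-closed amine, so a modest move back toward the lower number is expected, about a 2.2-fold lower number from compound 3 to compound 4 (0.35 log units; beyond the scatter). Compound 4 is thus estimated at 8000 nM, with a range from 3500 nM to 18000 nM.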

Compound 4, half-maximal inhibitory concentration: 11700 nM
Compound 4: middle estimate off by 1.5-fold (0.17 log units), on the low side, within the range that was stated.
By their numbers in this assay, from the lowest: compounds 1, 4, 3 and 2 (each within the scatter of the next, the first and the last beyond it).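

In this assay, morpholin-4-yl on the carbonyl carbon cannot be told apart from butylamino (a 1.5-fold lower number from compound 3 to compound 4 (0.18 log units; within the scatter)) or from pyrrolidin-1-yl (a 1.9-fold higher number from compound 1 to compound 4 (0.27 log units; within the scatter)). Only (4-methoxybenzyl)amino stands clearly apart (a 2.5-fold lower number from compound 2 to compound 4 (0.40 log units; beyond the scatter)). The closed ring of compound 4 therefore does not repeat the clear gap that separates compound 1 from compound 3, so a closed ring alone does not set the number here.

On these data alone, it remains open whether a piperidin-1-yl or piperazin-1-yl group on this carbonyl carbon would fall with compound 1 or compound 4. No evidence is available to explain these differences.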